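Lengthening the saturated chain of a limit-bound amide

A few compounds are considered here, and "the series" means these few. Any claim that something is new, unique, unknown or untested is made for them only; others in the source may bear on it.

Compound 2 `CCCCCCCCCCCCNC(=O)[C@@H](NC(=O)/C=C/c1ccccc1)[C@@H](C)O` is known only through a limit in a functional assay on HepG2 cells (Homo sapiens) for cytotoxicity, read by MTT assay, with a stated time of 48 h; on this read-out higher numbers stand for weaker inhibition and lower numbers for stronger inhibition: its value of > 200000 nM is a limit of the assay, not a measured number (the limit of > 200000 nM in this assay, at which 1 of the 3 values shown sits). Its close relatives do give numbers in this assay: compound 1 `CCCCCCCCCCCCNC(=O)[C@@H](NC(=O)c1cccs1)[C@@H](C)O` gives 30100 nM and compound 3 `CCCCCCCCCCCCNC(=O)[C@@H](NS(=O)(=O)c1cccs1)[C@@H](C)O` gives 25900 nM, so compound 2 stands above both, as shown by an at least 6.6-fold higher number from compound 1 to compound 2 (0.82 log units; beyond the scatter) and an at least 7.7-fold lower number from compound 2 to compound 3 (0.88 log units; beyond the scatter). Compound 4 `CCCCCCCCCCCCCCNC(=O)[C@@H](NC(=O)/C=C/c1ccccc1)[C@@H](C)O` differs from compound 2 by ethyl in place of hydrogen on a saturated chain carbon, ten or more bonds along the chain from an amide-type nitrogen. Among the compounds with values here, none of the measured steps touches the saturated chain; each exchanges the group on the amine nitrogen. Compound 4 is therefore expected to remain at or near the limit, with a number no higher from compound 2 to compound 4 (the limit leaves the size open). The estimate for compound 4 is 200000 nM, ranging from 80000 nM to 500000 nM.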

Compound 4, half-maximal inhibitory concentration: 150000 nM
Beside the measured number, compound 4's estimate is 1.3-fold (0.12 log units) above it; the measured number falls inside the stated range.
By their numbers in this assay, from the lowest: compounds 3 and 1 (each within the scatter of the next); then compound 4. At a limit, above all of these: compound 2.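

Ethyl in place of hydrogen on the saturated chain is the first change at this position, and in this assay it gives an at least 1.3-fold lower number from compound 2 to compound 4 (0.12 log units; that floor lies within the scatter). Within the data shown here, compound 4 also provides the first measured number for a compound with the (2-phenylethenyl)carbonyl group. The true size of the step remains unknown, and it could be small or large: the limit of > 200000 nM in this assay, at which 1 of the 4 values shown sits.

On these data alone, it is open whether a shorter chain, or a chain ending in an amine or a carboxylic acid, would shift the number. As far as these compounds go, it is also open whether the same lengthening would act alike on compound 1 or compound 3.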